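Trading Benzyl for Isopropyl on a Ring Amine

A few compounds are considered here, and "the series" means these few. Any claim that something is new, unique, unknown or untested is made for them only; others in the source may bear on it.

Measured so far in a physicochemical assay for lipophilicity, read by HPLC; on this read-out lower numbers stand for lower lipophilicity and higher numbers for higher lipophilicity

- Compound 1 `CN(C)Cc1cccc(-c2ccc(NC(=O)Nc3cccnc3Oc3ccccc3C(C)(C)C)c(F)c2)c1` reads 5.5
- Compound 2 `CC(C)(C)c1ccccc1Oc1ncccc1NC(=O)Nc1ccc(OCC2CCN(Cc3ccccc3)CC2)cc1F` reads 5.8

Among the measured compounds shown here, only one neighbour is available for placing compound 2. In this assay compound 2 gives 5.8 and compound 1 gives 5.5 so the pair lies within the usual scatter of repeated measurements, and the two cannot be told apart.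

Compound 3 `CC(C)N1CCC(COc2ccc(NC(=O)Nc3cccnc3Oc3ccccc3C(C)(C)C)c(F)c2)CC1` keeps the rest of compound 2 and changes one group: isopropyl in place of benzyl on an amine nitrogen in a ring with isopropyl in place of benzyl on an amine nitrogen in a ring. For the measured compounds named here, no two measured compounds show this swap, so the data offer no direct precedent for its size. The group that leaves is the larger one and carries a ring, whereas the group that enters has none. Starting from compound 2 at 5.8 a moderate downward move in this assay is therefore expected, larger than the scatter. The expected size of that move is a number 0.80 log units lower from compound 2 to compound 3 (beyond the scatter) on the estimate made here. The estimate for compound 3 is 5 within an expected range of 4.5 to 5.5 for the coming measurement.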

Compound 3, partition coefficient: 3.8
Estimate against measurement, compound 3: 1.20 log units above; measured number outside the range, below it.
By their numbers in this assay, from the lowest: compound 3; then compounds 1 and 2 (each within the scatter of the next).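

On the amine nitrogen in a ring, isopropyl in place of benzyl gives a large shift in this assay, a number 2.00 log units lower from compound 2 to compound 3 (beyond the scatter), so this one position can move the read-out far, which compounds 1 and 2, two compounds that could not be told apart, gave no means of seeing. Among the compounds shown here, compound 3 also stands clearly apart from the other measured compound, with (1-isopropylpiperidin-4-yl)methoxy in place of 3-((dimethylamino)methyl)phenyl on an aromatic carbon giving a number 1.70 log units lower from compound 1 to compound 3 (beyond the scatter), so it is the only compound of the three separated from the others beyond the scatter. Nothing measured here speaks to what lies behind the size of this step.

This single swap changes two things at once, removing the six-membered aromatic ring and reducing the number of carbons in the group, and the compounds shown leave open how much of the step belongs to each. A cyclohexyl on the same nitrogen, which keeps a ring without being aromatic, or a methyl, which carries fewer carbons still, would help separate the two.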